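Chain acid for chain alcohol: a step between limits

The compounds below may be only part of what the source reports. "The series", "measured", "known", "first", "only" and "open" are said of these compounds alone.

Three compounds have been run in an assay on 32D cells for inhibition of interleukin-15 (Mus musculus), read by resazurin assay, with stated times of 30 min and 2.5 days, in the presence of a further agent that is not named here; a lower number here means a stronger inhibitor, a higher number a weaker inhibitor:

compound 1 `Cn1nc(Cc2nnc(SCC(=O)Nc3ccc(Cl)cc3Cl)n2CCCO)c2ccccc2c1=O`: > 30000 nM, a limit of the assay, not a number.
compound 2 `Cn1nc(Cc2nnc(SCC(=O)Nc3ccc(Cl)cc3Cl)n2CCC(=O)O)c2ccccc2c1=O`: > 30000 nM, likewise a limit.
compound 3 `Cn1nc(Cc2nnc(SCCCCCCCC(=O)Nc3ccc(Cl)cc3Cl)n2CCCO)c2ccccc2c1=O`: > 30000 nM, likewise a limit.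

Compound 1 and compound 2 share a core and differ in one place: carboxy in place of hydroxymethyl on a saturated chain carbon, two bonds along the chain from an aromatic nitrogen. In this assay, for the measured compounds named here, the step that the two limits leave unreadable from compound 1 to compound 2 cannot be sized, because of the limit of > 30000 nM in this assay, at which 3 of the 3 values shown sit, so the pair shows only that neither member reaches a measurable value.

Compound 4 `Cn1nc(Cc2nnc(SCCCCCCCC(=O)Nc3ccc(Cl)cc3Cl)n2CCC(=O)O)c2ccccc2c1=O` is not yet measured. It stands to compound 3 as compound 2 stands to compound 1: carboxy in place of hydroxymethyl on a saturated chain carbon, two bonds along the chain from an aromatic nitrogen, the same change at the same place. How the core of compound 3 relates to the core of compound 1 is not broken down here.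

Going by the values given here, the expectation for compound 4 rests on two things: the value of compound 3 in this assay is a limit, > 30000 nM, and the only measured instance of this change, from compound 1 to compound 2, left both partners at a limit. It is therefore expected that the step that the limit leaves unreadable from compound 3 to compound 4 stays within the range that the assay cannot resolve. In this assay compound 4 is estimated at 40000 nM, with a plausible span of 10000 nM to 150000 nM, and the most likely outcome is a further limit rather than a number.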

Compound 4, half-maximal inhibitory concentration: > 30000 nM
Compound 4 gave a limit, no number; the forecaster's own chance of this, stated with the estimate: 85%; the middle value lies beyond the limit too.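

In this assay compound 4 gives > 30000 nM, a limit of the assay and not a number. For the compounds shown here, no step from compound 3 to compound 4 can be read, because both compounds sit at a limit: the limit of > 30000 nM in this assay, at which 4 of the 4 values shown sit. The compounds shown leave open whether carboxy in place of hydroxymethyl shifts the read-out at all, and what on this series would give a measurable value.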